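The compounds below may be only part of what the source reports. "The series", "measured", "known", "first", "only" and "open" are said of these compounds alone.

Three compounds with a shared core were tested in a functional assay on SMMC-7721 cells (Homo sapiens) for antiproliferative activity, read by MTT assay, with a stated time of 72 h; a lower number here means a stronger inhibitor, a higher number a weaker inhibitor. Compound 1 `CN(C(=O)c1ccccc1)c1ccc2[nH]c(-c3n[nH]c4ccccc34)cc2n1` gives 12500 nM. Compound 2 `COc1cccc(C(=O)N(C)c2ccc3[nH]c(-c4n[nH]c5ccccc45)cc3n2)c1`, which carries a methoxy in place of hydrogen on an aromatic carbon, gives 22000 nM. Compound 3 `CN(C(=O)c1ccco1)c1ccc2[nH]c(-c3n[nH]c4ccccc34)cc2n1`, with a furan-2-yl in place of phenyl on the carbonyl carbon, gives 28200 nM. Of these three numbers compound 1 has the lowest, yet the step of a 1.8-fold higher number from compound 1 to compound 2 (0.25 log units; within the scatter) falls within the scatter, while the step of a 2.3-fold higher number from compound 1 to compound 3 (0.35 log units; beyond the scatter) lies just beyond it and is modest. The step of a 1.3-fold higher number from compound 2 to compound 3 (0.11 log units; within the scatter) is within the scatter.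

Compound 4 `CN(C(=O)c1ccccc1)c1ccc2[nH]c(-c3n[nH]c4cc(Cl)ccc34)cc2n1` has not yet been measured. It differs from compound 1 by chloro in place of hydrogen on an aromatic carbon; the new group sits on an aromatic carbon of a six-membered aromatic ring of carbon only, part of a fused or bridged system of two rings, meta to a fused ring and para to a fused ring. Within the data shown here, none of the measured steps touches this part of the molecule: the steps from compound 1 concern only the group on the carbonyl carbon. Among the measured compounds shown here, there is thus no measured step that bears directly on this change, and the measured changes elsewhere were small. The expectation for compound 4 in this assay is therefore a step of a 1.0-fold lower number from compound 1 to compound 4 (0.02 log units; within the scatter), that is, no change beyond the scatter. The estimate for compound 4 is 12000 nM, with a range from 5000 nM to 30000 nM.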

Compound 4, half-maximal inhibitory concentration: 11300 nM
Estimate against measurement, compound 4: 1.1-fold (0.03 log units) above, within the range that was stated.
By their numbers in this assay, from the lowest: compounds 4, 1, 2 and 3 (each within the scatter of the next, the first and the last beyond it).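

In this assay the chloro on this aromatic carbon, which is meta to a fused ring and para to a fused ring, gives a 1.1-fold lower number from compound 1 to compound 4 (0.04 log units; within the scatter) and so leaves the number where it was within the usual scatter. The earlier compounds shown here differed only in the group on the carbonyl carbon and said nothing about this ring, whereas this result shows that one added chlorine atom at this place can be accepted with no gain or loss that can be told apart from the scatter. No information at hand explains this outcome.

Going by these compounds, a single small group at a single place does not show how far this acceptance extends, so the effect of an amine, a carboxylic acid or a longer chain on the same carbon remains open. Also open, on these data alone, is whether the chloro would behave the same way on the other carbons of this ring, or in compounds that carry the 3-methoxyphenyl or the furan-2-yl on the carbonyl carbon.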